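The source may report more compounds than this note shows. Statements on the series, on what has been measured and on what is new or still open speak of the compounds shown alone.

Measured compounds:
- compound 1, `CCn1c(C(=O)Nc2ccc(OC(F)(F)F)cc2)ccc1C(CC)(CC)c1ccc(OCCC(O)(CC)CC)c(C)c1`: in a functional assay on Caco-2 cells (Homo sapiens) for antiproliferative activity, read by MTT assay, with a stated time of 48 h (a higher number here means a weaker inhibitor, a lower number a stronger inhibitor), compound 1 gives > 50000 nM, a limit of the assay.
- compound 2, `CCC(C)C(CO)NC(=O)c1ccc(C(CC)(CC)c2ccc(OCCC(O)(CC)CC)c(C)c2)n1CC`: in this assay compound 2 gives > 50000 nM, also a limit of the assay.

Among the measured compounds shown here, compound 1 therefore stands only at a limit in this assay, and the one further value is a limit as well, so the limit of > 50000 nM in this assay, at which 2 of the 2 values shown sit, holds for everything measured so far. For the measured compounds named here, the single step with one change, a step that the two limits leave unreadable from compound 1 to compound 2, puts a branched hydroxyalkyl group in place of the aryl group on the amide-type nitrogen, and its size cannot be read.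

Compound 3, `CCn1c(C(=O)NC(CO)CCO)ccc1C(CC)(CC)c1ccc(OCCC(O)(CC)CC)c(C)c1`, differs from compound 1 by 3-hydroxy-1-(hydroxymethyl)propyl in place of 4-(trifluoromethoxy)phenyl on an amide-type nitrogen. Going by the values given here, this change resembles the one from compound 1 to compound 2, which also replaced the aryl group on the amide-type nitrogen with a hydroxyalkyl chain, and that step gave no readable size. Compound 3 is expected to sit at the limit again, with a step that the limit leaves unreadable from compound 1 to compound 3 most likely not readable. Compound 3 is estimated at 70000 nM, between 30000 nM and 300000 nM.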

Compound 3, half-maximal inhibitory concentration: 40200 nM
Beside the measured number, compound 3's estimate is 1.7-fold (0.24 log units) above it; low and high end bracket the measured number.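

In this assay compound 3 gives 40200 nM, the only value of the three shown that is a number and not a limit of the assay, so a change on the amide-type nitrogen bound to the carbonyl carbon has now produced a readable value. With 3-hydroxy-1-(hydroxymethyl)propyl in place of 4-(trifluoromethoxy)phenyl, the result is an at least 1.2-fold lower number from compound 1 to compound 3 (0.09 log units; that floor lies within the scatter), and with 2-hydroxyethyl in place of sec-butyl on the saturated chain carbon bound to an amide-type nitrogen and a saturated chain carbon, it is an at least 1.2-fold lower number from compound 2 to compound 3 (0.09 log units; that floor lies within the scatter). Both steps are floors only, so they fix no true size and do not establish a gain in activity, and the series remains dominated by a limit: the limit of > 50000 nM in this assay, at which 2 of the 3 values shown sit.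

Whether the hydroxyl of the 2-hydroxyethyl group accounts for the value of compound 3 stays open, and a 2-aminoethyl group, a carboxymethyl group or a longer 3-hydroxypropyl chain on the same saturated chain carbon would bear on that question. Also open, from the compounds shown here alone, is whether the full size of either step reaches beyond the scatter of this kind of measurement.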